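This account rests on a few compounds, and the source may have more. Where it says the series, first, only, none or still open, it means among the compounds named here.

Measured compounds:
Compound 1, `C=CCc1ccc(OCc2cn(-c3ccccc3CO)nn2)c(O)c1`: 4.2%
Compound 2, `C=CCc1cc(O)c(O)c(CN2CCC(CO)CC2)c1`: 4.7%

Both compounds were examined in a functional assay on HepG2 cells (Homo sapiens) for inhibition, read by MTT assay, with a stated time of 72 h, tested at 30 uM; on this read-out lower numbers stand for less inhibition of growth and higher numbers for more inhibition of growth at the one concentration tested. Compound 1 gives 4.2%, and compound 2 gives 4.7%. Compound 2 holds the highest of the two numbers, but its nearest neighbour, compound 1, lies only a little lower, and the gap between them is within the scatter, so the two compounds cannot be told apart on these figures. Both sit close to no inhibition of growth at the single concentration tested.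

The step from compound 2 leads to compound 3, `C=CCc1cc(O)c(O)c(CN2CCC(CCO)CC2)c1`, which has not yet been measured in this assay. The change is hydroxymethyl in place of hydroxy on a saturated chain carbon bound to a saturated ring carbon. Among the measured compounds shown here, no pair of measured compounds differing in one place is available, so the size of this kind of step cannot be read from the data. For the measured compounds named here, since the compounds measured so far both lie near the bottom of the scale, compound 3 is expected to stay there as well, with a change beyond the scatter in neither direction. For compound 3 the estimate is 5%, ranging from 0% to 15%, which means an expected step of a number 0.3 percentage points higher from compound 2 to compound 3 (within the scatter).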

Compound 3, percent growth inhibition at one concentration: 2.5%
Beside the measured number, compound 3's estimate is 2.5 percentage points above it, and the stated range covers the measured number.
By their numbers in this assay, from the lowest: compounds 3, 1 and 2 (each within the scatter of the next).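

In this assay, among the compounds shown here, the first step that can be read at this position is a number 2.2 percentage points lower from compound 2 to compound 3 (within the scatter) and it stays within the usual scatter. The earlier compounds shown here gave no size for any change in one place, whereas this pair shows that hydroxymethyl in place of hydroxy on a saturated chain carbon bound to a saturated ring carbon, which also reads as hydroxymethyl to 2-hydroxyethyl, leaves the number near no inhibition of growth at the one concentration tested. No measurement given here bears on this result or offers a reason for it.

Both compounds of this pair lie near the bottom of the scale, so the step says little about how the same change would act on a compound with a clearly higher number in this assay and cannot show that the position is indifferent to change in general. Going by these compounds, it remains open whether an amine or a carboxylic acid at the end of this chain, or a chain longer than 2-hydroxyethyl, would carry the number beyond the scatter.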